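A few compounds are considered here, and "the series" means these few. Any claim that something is new, unique, unknown or untested is made for them only; others in the source may bear on it.

Among the measured compounds shown here, compound 2, with the structure `Cc1nc(-c2ccc(C(F)(F)F)cc2)sc1CNc1ccc([C@H]2C[C@@H]2C(N)=O)cc1`, is the more potent of the two compounds measured so far in a functional assay on CHO cells for agonist activity at Free fatty acid receptor 1 (Homo sapiens); a higher number here means that more compound is needed for the effect, a lower number that less compound is needed: in this assay compound 2 gives 4.47 nM. For the measured compounds named here, its only comparison is compound 1, with the structure `Cc1nc(-c2ccc(C(F)(F)F)cc2)sc1CNc1ccc(CCC(=O)O)cc1`, which in this assay gives 67.6 nM; the step of a 15-fold lower number from compound 1 to compound 2 (1.18 log units; beyond the scatter) is the one measured change, and it swapped an entire side chain rather than a single group.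

Compound 3, with the structure `Cc1nc(-c2ccc(C(F)(F)F)cc2)sc1CNc1ccc([C@H]2C[C@@H]2C(=O)N(C)C)cc1`, keeps everything of compound 2 except at the end of the cyclopropyl side chain, where the change is dimethylamino in place of amino on a carbonyl carbon. Going by the values given here, no measured step touches this part of the molecule: the one step known, from a carboxylic acid chain to the carbamoylcyclopropyl group, says nothing about what happens when both hydrogens of that amide nitrogen are replaced by methyl groups. Among the compounds with values here, the expectation therefore rests on no direct precedent, and a step near the scatter in either direction is expected, perhaps a slight loss; compound 3 is expected to give 8 nM, between 2.5 nM and 25 nM, a step of a 1.8-fold higher number from compound 2 to compound 3 (0.25 log units; within the scatter).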

Compound 3, half-maximal effective concentration: 66.1 nM
Compound 3: middle estimate off by 8.3-fold (0.92 log units), on the low side, outside the stated range (above it).
By their numbers in this assay, from the lowest: compound 2; then compounds 3 and 1 (each within the scatter of the next).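

In this assay, the end of the cyclopropyl side chain proves to be a place where a small change counts: dimethylamino in place of amino on the carbonyl carbon gives a 15-fold higher number from compound 2 to compound 3 (1.17 log units; beyond the scatter) and so removes the whole advantage of compound 2. The gain seen earlier therefore does not come from the cyclopropyl side chain alone, since 2-(dimethylcarbamoyl)cyclopropyl in place of 2-carboxyethyl gives a 1.0-fold lower number from compound 1 to compound 3 (0.01 log units; within the scatter) in the same assay, so the primary amide matters as well as the chain that carries it. This change takes away a hydrogen-bond donor and adds two carbon atoms at once, and nothing available here separates those two parts of the change or accounts for the loss.

From the compounds shown here alone, a single methyl group on the amide nitrogen would help to show whether one replaced hydrogen is already enough to produce the loss, and that case remains open. Also open, going by these compounds, is how a carboxylic acid placed directly on the cyclopropyl ring would compare with the primary amide of compound 2, as a change made at this one place.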